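Removing the Furan Methyl: A Small Step Examined

The compounds below may be only part of what the source reports. "The series", "measured", "known", "first", "only" and "open" are said of these compounds alone.

Measured so far:
- compound 1 `Cc1ccc(-c2nc(CNc3ccc(C(=O)NO)cc3)n(-c3ccccc3)n2)o1` — 60.7%
- compound 2 `O=C(NO)c1ccc(NCc2nc(-c3cccs3)nn2-c2ccc(O)cc2)cc1` — 79.6%
- compound 3 `COc1ccc(-n2nc(-c3ccccc3)nc2CNc2ccc(C(=O)NO)cc2)cc1` — 63.4%

Of the compounds shown here, three share a core and have been tested in an assay on Sf9 cells for inhibition of protein deacetylase HDAC6 (Homo sapiens), read by fluorescence, with a stated time of 40 min, tested at 100 nM; on this read-out lower numbers stand for less inhibition and higher numbers for more inhibition at the one concentration tested (going by the name of the read-out). Compound 1 `Cc1ccc(-c2nc(CNc3ccc(C(=O)NO)cc3)n(-c3ccccc3)n2)o1` gives 60.7% in this assay, the lowest of the three numbers. The nearest is compound 3, whose value of 63.4% lies within the usual scatter of compound 1, so no order between them can be read. Compound 2, at 79.6%, sits beyond the scatter above compound 1; no single-point difference between these two is described, so only the two values themselves are known.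

Compound 4 `O=C(NO)c1ccc(NCc2nc(-c3ccco3)nn2-c2ccccc2)cc1` has not yet been measured. It differs from compound 1 in one place: hydrogen in place of methyl on an aromatic carbon. For the measured compounds named here, no pair of measured compounds shows this change, so the expected size of the step is uncertain. The change is small, and compound 4 is therefore expected to stay close to compound 1, with a step of a number 3.7 percentage points lower from compound 1 to compound 4 (within the scatter) that is expected to fall within the scatter. Compound 4 is estimated at 57%, with a range of 42% to 72%.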

Compound 4, a percentage reported as inhibition, at one concentration (the size of the read-out at that concentration, not a potency): 59.9%
Estimate against measurement, compound 4: 2.9 percentage points below; the range from low to high includes it.
By their numbers in this assay, from the lowest: compounds 4, 1 and 3 (each within the scatter of the next); then compound 2.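

In this assay, for the compounds shown here, the change from 5-methylfuran-2-yl to furan-2-yl gives the first step in this set that differs in one place only, and it reads a number 0.8 percentage points lower from compound 1 to compound 4 (within the scatter). On the core of compound 1, the methyl next to the ring oxygen can therefore be replaced by hydrogen without a change that this single-concentration read-out can separate from scatter. Nothing measured here explains this result.

On these data alone, whether other groups at this position would leave the number level stays open, since an amine, a carboxylic acid or a longer chain at the same ring carbon could give a different number. As far as these compounds go, it is also open whether replacing this methyl by hydrogen would give a similarly small step on a core carrying other substituents.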